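This account rests on a few compounds, and the source may have more. Where it says the series, first, only, none or still open, it means among the compounds named here.

Measured in a functional assay on THP-1 cells (Homo sapiens) for inhibition; on this read-out higher numbers stand for weaker inhibition of growth and lower numbers for stronger inhibition of growth:
- compound 1 `Cc1noc(C)c1-c1ccc2c(c1)c(Cc1ccc(F)cc1)cn2CCCCCC(=O)NO`: 15500 nM
- compound 2 `Cc1ccc(Cc2cn(CCCCCC(=O)NO)c3ccc(-c4c(C)noc4C)cc23)cc1`: 15500 nM
- compound 3 `Cc1noc(C)c1-c1ccc2c(c1)c(Cc1cccc(C(F)(F)F)c1)cn2CCCCCC(=O)NO`: not yet measured

Compound 2, at 15500 nM, stands level with compound 1. The change now followed is 3-(trifluoromethyl)phenyl in place of 4-methylphenyl on a saturated chain carbon bound to an aromatic carbon. Among the compounds with values here, one measured step bears on it, no change at the digits printed from compound 1 to compound 2 (within the scatter), and that step also concerned the aromatic ring of the 4-methylphenyl group. Going by that single step, no shift beyond the scatter is expected in this assay, although no measured compound carries a trifluoromethyl group. The expected step is a 1.0-fold lower number from compound 2 to compound 3 (0.01 log units; within the scatter). For compound 3 the estimate is 15000 nM, within an expected range of 6500 nM to 32000 nM.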

Compound 3, concentration for 50% growth inhibition: 15500 nM
Estimate against measurement, compound 3: 1.0-fold (0.01 log units) below; measured number inside the range.
By their numbers in this assay, from the lowest: compounds 1, 2 and 3 (each within the scatter of the next).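

In this assay, exchanging 4-methylphenyl for 3-(trifluoromethyl)phenyl on a saturated chain carbon bound to an aromatic carbon, which takes the group from 7 to 10 heavy atoms, gives a flat step (no change at the digits printed from compound 2 to compound 3 (within the scatter)). Exchanging 4-fluorophenyl for the same group reads the same (no change at the digits printed from compound 1 to compound 3 (within the scatter)). So this position accepts a larger group carrying its substituent at a different ring position with no shift in the read-out, and nothing available explains this flatness.

From the compounds shown here alone, what a carboxylic acid or an amine on this ring would do in this assay stays open, as does whether any group at this position can shift the number at all.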